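Compound 3 to compound 4: butylcarbonyl for 3-(dimethylamino)propyl

A few compounds are considered here, and "the series" means these few. Any claim that something is new, unique, unknown or untested is made for them only; others in the source may bear on it.

In a functional assay on K562 cells (Homo sapiens) for cytotoxicity, read by MTT assay (a higher number here means a weaker inhibitor, a lower number a stronger inhibitor), compound 1 (`COc1ccc(/C=C/C(=O)c2ccc(OC)c3c2OC(C)(C)C=C3)cc1OCC=C(C)C`) reads > 10000 nM, which is a limit of the assay. Compound 2 (`C#CCOc1cc(/C=C/C(=O)c2ccc(OC)c3c2OC(C)(C)C=C3)ccc1OC`) reads > 10000 nM, also a limit. Among the compounds with values here, compound 3 (`COc1ccc(/C=C/C(=O)c2ccc(OC)c3c2OC(C)(C)C=C3)cc1OCCCN(C)C`) gives 2920 nM, the only actual number so far. Compound 4 (`CCCCC(=O)Oc1cc(/C=C/C(=O)c2ccc(OC)c3c2OC(C)(C)C=C3)ccc1OC`) carries butylcarbonyl in place of 3-(dimethylamino)propyl on an oxygen on an aromatic ring. Within the data shown here, two steps bear on this change: an at least 3.4-fold lower number from compound 1 to compound 3 (0.53 log units; beyond the scatter) and an at least 3.4-fold lower number from compound 2 to compound 3 (0.53 log units; beyond the scatter). Both lie beyond the scatter and both end at the dimethylamino chain, which compound 4 gives up. A move to a higher number in this assay is therefore expected. The expected size is a 4.1-fold higher number from compound 3 to compound 4 (0.61 log units; beyond the scatter). The estimated value for compound 4 is 12000 nM, with an expected range of 5000 nM to 30000 nM.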

Compound 4, half-maximal inhibitory concentration: 240 nM
Beside the measured number, compound 4's estimate is 50-fold (1.70 log units) above it; measured number outside the range, below it.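

In this assay, butylcarbonyl on the oxygen on an aromatic ring gives a 12-fold lower number from compound 3 to compound 4 (1.09 log units; beyond the scatter), so a nitrogen in the chain is not required for a low number at this position. Against the propargyl and 3-methylbut-2-en-1-yl groups, the steps are an at least 41-fold lower number from compound 2 to compound 4 (1.61 log units; beyond the scatter) and an at least 41-fold lower number from compound 1 to compound 4 (1.61 log units; beyond the scatter), and both are bounds only. Compound 1 and compound 2 each stand at a limit of the assay, not at a number: the limit of > 10000 nM in this assay, at which 2 of the 4 values shown sit.

On these data alone, whether the carbonyl or the chain length carries the step stays open. An acetyl group, a longer acyl chain or a free hydroxyl on this oxygen would separate the two.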